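Clearance notes: chloro to methyl from compound 3

The compounds below may be only part of what the source reports. "The series", "measured", "known", "first", "only" and "open" are said of these compounds alone.

Values measured so far in an in vitro ADME assay on microsomes from Gut (Homo sapiens) for metabolic stability, using NADPH; on this read-out lower numbers stand for slow clearance and higher numbers for fast clearance
- compound 1 `CC(C)(CO)CNC(=O)c1cc2cc(C#N)ccc2n1Cc1cccc(OC(F)(F)F)c1` gives < 6 mL.min-1.g-1
- compound 2 `CCOc1ccc(OC(F)(F)F)cc1Cn1c(C(=O)NCC(C)(C)CO)cc2cc(C#N)ccc21` gives < 6 mL.min-1.g-1
- compound 3 `COc1ccc(Cl)cc1Cn1c(C(=O)NCC(C)(C)CO)cc2cc(C#N)ccc21` gives < 6 mL.min-1.g-1

Compound 3 stands at < 6 mL.min-1.g-1 as a limit of the assay and not as a number. Compound 1 and compound 2 also give only a limit each, so no order among the three can be read.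

Compound 4 `COc1ccc(C)cc1Cn1c(C(=O)NCC(C)(C)CO)cc2cc(C#N)ccc21` differs from compound 3 by methyl in place of chloro on an aromatic carbon, para to a methoxy group (methyl in place of chloro on an aromatic carbon) and in nothing else. Within the data shown here, this change has no measured counterpart. Among the measured compounds shown here, the one measured step is a step that the two limits leave unreadable from compound 1 to compound 2 with ethoxy in place of hydrogen on an aromatic carbon, a different change whose size cannot be read.

The expectation therefore rests on compound 3 sharing the limit of < 6 mL.min-1.g-1 in this assay, at which 3 of the 3 values shown sit, with both other compounds. The expected step is a step that the limit leaves unreadable from compound 3 to compound 4 in this assay and it is not expected to exceed the scatter, with no direction supported by the data. For compound 4 the estimate is 5 mL.min-1.g-1 with an expected range from 3 mL.min-1.g-1 to 11 mL.min-1.g-1 and a report as a limit is the likeliest outcome.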

Compound 4, intrinsic clearance in microsomes: < 6 mL.min-1.g-1
Compound 4: a limit, no number; the forecaster's own chance of this, stated with the estimate: 75%; the middle value lies beyond the limit too.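

In this assay compound 4 gives < 6 mL.min-1.g-1, which is a limit and not a number. Compound 3 also gives only a limit, so no step between compound 3 and compound 4 can be read: the limit of < 6 mL.min-1.g-1 in this assay, at which 4 of the 4 values shown sit.

The compounds shown leave open where the actual clearance of each lies and whether methyl in place of chloro alters it.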